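A few compounds are considered here, and "the series" means these few. Any claim that something is new, unique, unknown or untested is made for them only; others in the source may bear on it.

Compound 1, `COc1ccc(CCOc2ccc(-c3c(C)nc(C)c([C@H](OC(C)(C)C)C(=O)O)c3N3CCC(C)(C)CC3)cc2)cc1`: in an ADME assay on microsomes from liver (Homo sapiens) for metabolic stability, read by LC-MS, tested at 0.5 uM (on this read-out higher numbers stand for a longer-lived compound and lower numbers for a shorter-lived compound), compound 1 gives > 2 h, which is a limit of the assay rather than a number.
Compound 2, `Cc1cc(CCOc2ccc(-c3c(C)nc(C)c([C@H](OC(C)(C)C)C(=O)O)c3N3CCC(C)(C)CC3)cc2)ccc1F`: in this assay compound 2 gives > 2 h, again a limit.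
Compound 3, `Cc1nc(C)c([C@H](OC(C)(C)C)C(=O)O)c(N2CCC(C)(C)CC2)c1-c1ccc(OCCc2cc(F)c(F)cc2F)cc1`: in this assay compound 3 gives > 2 h, also a limit.

Compound 3 therefore stands at the limit of this assay, and so does every other value shown, as the limit of > 2 h in this assay, at which 3 of the 3 values shown sit, records. The three measured steps that link these compounds are accordingly not readable: a step that the two limits leave unreadable from compound 1 to compound 2, a step that the two limits leave unreadable from compound 1 to compound 3 and a step that the two limits leave unreadable from compound 2 to compound 3.

Compound 4, `Cc1nc(C)c([C@H](OC(C)(C)C)C(=O)O)c(N2CCC(C)(C)CC2)c1-c1ccc(CCCc2ccc(F)cc2)cc1`, has not yet been measured in this assay. It differs from compound 3 in one place: 3-(4-fluorophenyl)propyl in place of 2-(2,4,5-trifluorophenyl)ethoxy on an aromatic carbon. For the measured compounds named here, none of the measured steps touches this kind of change, since each of them swaps one substituted phenyl for another while keeping the ethoxy link, and none of them yields a readable size. Going by the values given here, what is known is only that compound 3 and both of its neighbours sit at the limit.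

On that basis compound 4 is expected to remain long-lived in this assay, most likely at the limit again, so that the step from compound 3 to compound 4 is estimated as a step that the limit leaves unreadable from compound 3 to compound 4. The estimate for compound 4 is 2.5 h, with a range from 1.2 h to 5 h.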

Compound 4, half-life: > 2 h
Compound 4 gave a limit, no number (the forecaster's own chance of this, stated with the estimate: 65%); the middle value lies beyond the limit too.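

Compound 4 gives > 2 h in this assay, which is a limit of the assay and not a number. No step linking compound 4 to compound 1, compound 2 or compound 3 can therefore be read: the limit of > 2 h in this assay, at which 4 of the 4 values shown sit.

The compounds shown leave open how long any of them actually lasts, and so whether 3-(4-fluorophenyl)propyl in place of 2-(2,4,5-trifluorophenyl)ethoxy changes the half-life at all.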